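Notes on a chlorobenzyl swap carried across two cores

The source may hold more compounds than are shown below. What is called first, only, known or untested is meant among the compounds shown, and "the series" means these compounds.

Measured so far:
compound 1, `COc1ccc(C2N=C(SCc3cccc(Cl)c3)NC(C)=C2C(=O)Nc2ccc(F)cc2)cc1OC`: 15.5%
compound 2, `COc1ccc(C2N=C(SCc3ccc(Cl)cc3)NC(C)=C2C(=O)Nc2ccc(F)cc2)cc1OC`: 22.2%
compound 3, `CC1=C(C(=O)Nc2ccc([N+](=O)[O-])cc2)C(c2ccc(Br)cc2)N=C(SCc2cccc(Cl)c2)N1`: 2.6%

All three numbers come from a functional assay on the whole organism (artery, strain albino) with Rattus norvegicus as the target, with a stated time of 720 min, at a dose of 10 mg/kg by the oral route; a lower number here means less inhibition, a higher number more inhibition at the dose given (going by the name of the read-out). Compound 1 and compound 2 share one core and differ in a single place: 4-chlorophenyl in place of 3-chlorophenyl on a saturated chain carbon bound to a sulfur. The step of a number 6.7 percentage points higher from compound 1 to compound 2 (within the scatter). Compound 3 sits on another core; the difference between the core of compound 3 and the core of compound 1 is not broken down here. In this assay compound 3 gives the lowest of the three numbers, with compound 1 nearest and compound 2 furthest, both beyond the scatter.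

Compound 4, `CC1=C(C(=O)Nc2ccc([N+](=O)[O-])cc2)C(c2ccc(Br)cc2)N=C(SCc2ccc(Cl)cc2)N1`, is not yet measured. It stands to compound 3 as compound 2 stands to compound 1: 4-chlorophenyl in place of 3-chlorophenyl on a saturated chain carbon bound to a sulfur. The place is the same word for word, so this is the same change. For the measured compounds named here, the only guide is the one measured occurrence, and a step of similar size is expected, a number 5.4 percentage points higher from compound 3 to compound 4 (within the scatter), resting on a number 6.7 percentage points higher from compound 1 to compound 2 (within the scatter). Compound 4 is therefore estimated at 8%, with a range from 0% to 20%.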

Compound 4, a percentage reported as inhibition, in the whole organism at one dose (the size of the read-out at that dose, not a potency): 29.4%
Compound 4: middle estimate off by 21.4 percentage points, on the low side; the measured number lies above the stated range.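

The swap of 3-chlorophenyl for 4-chlorophenyl on a saturated chain carbon bound to a sulfur does not carry over at one size in this assay: the same change on two cores in this assay, a number 6.7 percentage points higher (within the scatter) from compound 1 to compound 2 and a number 26.8 percentage points higher (beyond the scatter) from compound 3 to compound 4, 20.1 percentage points apart, beyond the scatter of two such steps.
On the core of compound 3 the change gives a number 26.8 percentage points higher from compound 3 to compound 4 (beyond the scatter), while on the core of compound 1 its step stays inside the scatter, so the size of the step on one core was a poor guide to its size on the other.
This does not show which of the parts that separate the two cores sets the size of the step, and one pair on each core gives no rule for any further core.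

Only chlorobenzyl groups stand on the sulfur in the compounds shown, so how an unsubstituted benzyl, a methyl or a chain ending in an amine would read on either core remains open.
Also open, as far as these compounds go, is whether the larger step would hold on a third core in this assay.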